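Swapping a Side Chain on a Longer-Tailed Core

A few compounds are considered here, and "the series" means these few. Any claim that something is new, unique, unknown or untested is made for them only; others in the source may bear on it.

Four related compounds are compared in a functional assay on HeLa cells (Homo sapiens) for cytotoxicity, read by MTT assay, with a stated time of 48 h; a lower number here means a stronger inhibitor, a higher number a weaker inhibitor. Compound 1 `CCCCCCCCCC(=O)N[C@H](C(=O)Nc1ccn([C@H]2O[C@@H](CO)[C@H](O)[C@H]2O)c(=O)n1)C(C)C` gives 4990 nM. Compound 2 `CCCCCCCCCC(=O)N[C@@H](CCCNC(=N)N)C(=O)Nc1ccn([C@H]2O[C@@H](CO)[C@H](O)[C@H]2O)c(=O)n1` gives 6000 nM, and compound 3 `CCCCCCCCCCCCCCCCCC(=O)N[C@@H](CCCNC(=N)N)C(=O)Nc1ccn([C@H]2O[C@@H](CO)[C@H](O)[C@H]2O)c(=O)n1` gives 12100 nM. Compound 4 `CCCCCCCCCCCCCCCCCC(=O)N[C@H](C(=O)Nc1ccn([C@H]2O[C@@H](CO)[C@H](O)[C@H]2O)c(=O)n1)C(C)C` has not yet been measured.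

Compound 1 and compound 2 share one core and differ at a single spot: a group of 3 heavy atoms (3 carbon; no ring) in place of a group of 7 heavy atoms (4 carbon, 3 nitrogen; no ring), on a saturated chain carbon bound to an amide-type nitrogen and a carbonyl carbon. That exchange made a step of a 1.2-fold lower number from compound 2 to compound 1 (0.08 log units; within the scatter). Compound 3 and compound 4 sit on a second core, and the difference between the two cores is octyl in place of hydrogen on a saturated chain carbon, nine bonds along the chain from a carbonyl carbon; that change made a step of a 2.0-fold higher number from compound 2 to compound 3 (0.30 log units; within the scatter). On the second core the side-chain exchange is now made again: a group of 3 heavy atoms (3 carbon; no ring) in place of a group of 7 heavy atoms (4 carbon, 3 nitrogen; no ring), on a saturated chain carbon bound to an amide-type nitrogen and a carbonyl carbon. The spot where the group is exchanged is described in exactly the same words for both pairs, so this is the same change, not merely the same kind of change, and it occurs twice among these compounds.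

For the measured compounds named here, the only evidence for this swap is the step from compound 2 to compound 1, which stayed within the usual scatter. In this assay compound 4 is therefore expected to show a step of a 1.2-fold lower number from compound 3 to compound 4 (0.08 log units; within the scatter), resting on the earlier step of a 1.2-fold lower number from compound 2 to compound 1 (0.08 log units; within the scatter). The value of compound 4 is estimated at 10000 nM, with a likely range from 5000 nM to 20000 nM.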

Compound 4, half-maximal inhibitory concentration: 13000 nM
The estimate for compound 4 lay 1.3-fold (0.11 log units) below the measured number, and the stated range covers the measured number.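

Exchanging the side chain for isopropyl on the core of compound 3 gave a 1.1-fold higher number from compound 3 to compound 4 (0.03 log units; within the scatter) in this assay, and the two steps for this exchange agree, so it carried from one core to the other without a gap beyond the usual scatter: the same change on two cores in this assay, a 1.2-fold lower number (0.08 log units; within the scatter) from compound 2 to compound 1 and a 1.1-fold higher number (0.03 log units; within the scatter) from compound 3 to compound 4, 1.3-fold (0.11 log units) apart, within the scatter of two such steps. The octyl addition, read on the compounds that carry isopropyl, gave a 2.6-fold higher number from compound 1 to compound 4 (0.42 log units; beyond the scatter), a modest step beyond the scatter, and it also agrees with the same addition on the other side chain: the same change on two cores in this assay, a 2.0-fold higher number (0.30 log units; within the scatter) from compound 2 to compound 3 and a 2.6-fold higher number (0.42 log units; beyond the scatter) from compound 1 to compound 4, 1.3-fold (0.11 log units) apart, within the scatter of two such steps. For the compounds shown here, this does not show that the side chain has a readable effect in this assay, since both exchange steps lie within the scatter, and agreement between two steps of that size on only two cores is weak support for carrying the exchange to further cores.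

The compounds shown leave open whether a different side chain, such as one ending in an amine or a carboxylic acid, would give a step beyond the scatter and whether that step would hold on both cores. They also leave open how a still longer chain in the tail would read in this assay.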